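The source may report more compounds than this note shows. Statements on the series, on what has been measured and on what is new or still open speak of the compounds shown alone.

Of the compounds shown here, two have been measured in a functional assay on NT2 cells (Homo sapiens) for inhibition; a lower number here means a stronger inhibitor, a higher number a weaker inhibitor. Compound 1 `CCC(C(=O)N[C@@H](CC(=O)O)C(=O)CSCc1ccccc1)n1ccnc(NCC2COc3ccccc3O2)c1=O` gives 30 nM, the higher of the two numbers. Compound 2 `CCC(C(=O)N[C@@H](CC(=O)O)C(=O)CNCN1Cc2ccccc2C1)n1ccnc(NCc2nonc2C)c1=O` gives 1.52 nM, a lower number than compound 1, and the gap between the two lies beyond the scatter. Compound 2 differs from compound 1 in several places at once, so its value shows only that the two stand apart in this assay; no single change between them has been traced.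

Compound 3 `CCC(C(=O)N[C@@H](CC(=O)O)C(=O)CSCc1ccccc1)n1ccnc(NCCCOC)c1=O` has not yet been measured. It differs from compound 1 in one place: 2-methoxyethyl in place of 2,3-dihydro-1,4-benzodioxin-2-yl on a saturated chain carbon bound to a nitrogen on an aromatic ring The group that leaves brings two rings and two hydrogen-bond acceptors; the group that enters has no ring and one hydrogen-bond acceptor. Within the data shown here, no measured pair shows how such a change reads in this assay. A step toward a higher number, beyond the scatter, is expected, because compound 1 already gives 30 nM and the smaller group offers less. For compound 3 the estimated value is 100 nM, within a range of 25 nM to 400 nM. The expected step is a 3.3-fold higher number from compound 1 to compound 3 (0.52 log units; beyond the scatter).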

Compound 3, half-maximal inhibitory concentration: > 10 nM
Compound 3 ended at the assay's limit (the forecaster's own chance of this, stated with the estimate: 5%); the middle value does not contradict the limit.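

In this assay compound 3 gives > 10 nM, which is a limit of the assay and not a number. No step from compound 1 to compound 3 can be read from it: the limit of > 10 nM in this assay, at which 1 of the 3 values shown sits.

The compounds shown leave open whether 3-methoxypropyl in place of (2,3-dihydro-1,4-benzodioxin-2-yl)methyl changes the number in this assay at all, and by how much.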